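Replacing pyridin-3-yl with 4-fluorophenyl in compound 1

A few compounds are considered here, and "the series" means these few. Any claim that something is new, unique, unknown or untested is made for them only; others in the source may bear on it.

Compound 1 `CNC(=O)c1cc(C(=O)N[C@H]2[C@@H]3COC[C@@H]32)cc2c1OC[C@H]2c1cccnc1` gives >= 104 ug/mL
Compound 2 `CNC(=O)c1cc(C(=O)N[C@H]2[C@@H]3COC[C@@H]32)cc2c1OC[C@@]2(CO)c1ccccc1` gives >= 202 ug/mL
Compound 3 `CNC(=O)c1cc(C(=O)N[C@H]2[C@@H]3COC[C@@H]32)cc2c1O[C@H](CF)[C@H]2c1ccccc1` gives >= 206 ug/mL
Compound 4 `CNC(=O)c1cc(C(=O)N[C@H]2[C@@H]3COC[C@@H]32)cc2c1OC[C@H]2c1ccc(F)cc1` has not yet been measured

In a physicochemical assay for solubility (on this read-out higher numbers stand for higher solubility and lower numbers for lower solubility), compound 1 gives >= 104 ug/mL, which is a limit of the assay and not a number. Compound 2 and compound 3 also return only limits, so the three cannot be placed in order. Compound 4 differs from compound 1 as follows: 4-fluorophenyl in place of pyridin-3-yl on a saturated ring carbon. This puts 4-fluorophenyl in place of pyridin-3-yl on a saturated ring carbon. Going by the values given here, no measured pair differs in one place, so the data offer no direct guide, and no shift beyond the usual scatter is expected in this assay. The expected change is an at least 1.0-fold lower number from compound 1 to compound 4 (0.01 log units; that floor lies within the scatter). For compound 4 the estimated value is 100 ug/mL, with an expected range of 30 ug/mL to 220 ug/mL.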

Compound 4, solubility: >= 176 ug/mL
Compound 4 ended at the assay's limit; the forecaster's own chance of this, stated with the estimate: 45%; middle value at least 1.7-fold (0.24 log units) away from the limit.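

Compound 1 and compound 4 both give only limits, and the step between them cannot be read in this assay. The compounds shown leave open where the actual solubility of each compound lies.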